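The source may report more compounds than this note shows. Statements on the series, on what has been measured and on what is new or still open speak of the compounds shown alone.

Compound 1, `CC(C)CN1CCCC[C@H]1C(=O)Nc1cc(C(C)(C)C)on1`: 0.1 h
Compound 2, `CC(=O)N1CCN(C(=O)N2CCCC[C@H]2C(=O)Nc2cc(C(C)(C)C)on2)CC1`: > 2 h

Of the compounds shown here, two have been measured in an ADME assay (liver) for metabolic stability, with Liver microsome (Homo sapiens) as the target, read by LC-MS, using microsomes and NADPH, tested at 1 uM; on this read-out higher numbers stand for a longer-lived compound and lower numbers for a shorter-lived compound. Compound 1, with the structure `CC(C)CN1CCCC[C@H]1C(=O)Nc1cc(C(C)(C)C)on1`, gives 0.1 h. Compound 2, with the structure `CC(=O)N1CCN(C(=O)N2CCCC[C@H]2C(=O)Nc2cc(C(C)(C)C)on2)CC1`, is reported at > 2 h. That reading for compound 2 is a limit of the assay and not a number. Compound 2 thus stands at the long-lived end of what has been measured, and the limit of > 2 h in this assay, at which 1 of the 2 values shown sits, is the only statement of where it sits. For the measured compounds named here, no step between the two measured compounds is counted, since they differ in more than one place; what the two values show is a short half-life for compound 1 and a limit for compound 2.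

Compound 3, `CC(C)(C)c1cc(NC(=O)[C@@H]2CCCCN2C(=O)N2CC[S+]([O-])CC2)no1`, remains to be measured in this assay. Relative to compound 2 it carries a group of 7 heavy atoms (4 carbon, 1 nitrogen, 1 oxygen, 1 sulfur; one six-membered non-aromatic ring with 2 hetero atoms) in place of a group of 9 heavy atoms (6 carbon, 2 nitrogen, 1 oxygen; one six-membered non-aromatic ring with 2 hetero atoms), on a carbonyl carbon. Going by the values given here, with no measured step to lean on, the expected shift is a step that the limit leaves unreadable from compound 2 to compound 3, small and without a clear direction, inside the scatter of this assay. Compound 3 is therefore expected to give about 2.5 h, with a range from 1 h to 6 h, and it may well be reported only as a limit.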

Compound 3, half-life: > 2 h
Compound 3: a limit, no number; the forecaster's own chance of this, stated with the estimate: 60%; the middle value is on the limit's open side.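

In this assay compound 3 is reported at > 2 h, which is a limit of the assay and not a number. Setting the group of compound 3, with its carbonyl and its sulfur-bearing six-membered ring, on the amine nitrogen in a ring in place of the open chain of compound 1 goes with an at least 20-fold higher number from compound 1 to compound 3 (1.30 log units; beyond the scatter), which gives the set its first readable step. The step between compound 2 and compound 3 cannot be read, as both stand at a limit, so the exchange of the 4-acetylpiperazin-1-yl group on the carbonyl carbon for the sulfur-bearing ring shows only that the reading stays at the same limit: the limit of > 2 h in this assay, at which 2 of the 3 values shown sit.

The compounds shown leave open how far past the limit compound 2 and compound 3 lie, and so whether the two differ at all in this assay. They also leave open whether a morpholine ring or an open-chain dimethylamino group on that carbonyl carbon would stay at the limit as well, or whether the reading would fall back towards that of compound 1.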